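Oxan-4-yl to 1-methylpyrrolidin-2-yl on the carbonyl carbon

The compounds below may be only part of what the source reports. "The series", "measured", "known", "first", "only" and "open" are said of these compounds alone.

In a functional assay on A2780 cells (Homo sapiens) for antiproliferative activity, read by CellTiter-Glo, with a stated time of 72 h (on this read-out higher numbers stand for weaker inhibition and lower numbers for stronger inhibition), compound 3 `C[C@H](NC(=O)C1CCOCC1)c1ccc(NC(=O)N2CC(c3ccc(N)nc3)C2)cc1` gives 46 nM, the highest of three numbers. Compound 1 `C[C@H](NC(=O)[C@@H]1CCCN1C)c1ccc(NC(=O)N2CC(c3cccnc3)C2)cc1` gives 5.7 nM and compound 2 `C[C@@H](c1ccc(NC(=O)N2CC(c3ccc(N)nc3)C2)cc1)N1Cc2ccccc2C1=O` gives 5.9 nM, each beyond the scatter from compound 3.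

Compound 4 `C[C@H](NC(=O)[C@@H]1CCCN1C)c1ccc(NC(=O)N2CC(c3ccc(N)nc3)C2)cc1` differs from compound 3 by 1-methylpyrrolidin-2-yl in place of oxan-4-yl on a carbonyl carbon. Within the data shown here, the one measured step that bears on this part of the structure is a 7.8-fold higher number from compound 2 to compound 3 (0.89 log units; beyond the scatter), a modest step beyond the scatter, though from a different group. Compound 1 also carries 1-methylpyrrolidin-2-yl on a carbonyl carbon, differs elsewhere, and stands at 5.7 nM, so a lower number is expected, in a step of similar size. The expected change in this assay is a 5.8-fold lower number from compound 3 to compound 4 (0.76 log units; beyond the scatter). For compound 4 the estimated value is 8 nM, with an expected range of 3 nM to 22 nM.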

Compound 4, half-maximal inhibitory concentration in the A2780 assay: 11 nM
Compound 4: middle estimate off by 1.4-fold (0.14 log units), on the low side; low and high end bracket the measured number.
By their numbers in the A2780 assay, from the lowest: compounds 1, 2 and 4 (each within the scatter of the next); then compound 3.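

Among these compounds, in the A2780 assay, the direct swap on the carbonyl carbon gives a 4.2-fold lower number from compound 3 to compound 4 (0.62 log units; beyond the scatter), the first matched reading of 1-methylpyrrolidin-2-yl against oxan-4-yl at this position. Amino in place of hydrogen on an aromatic carbon gives a 1.9-fold higher number from compound 1 to compound 4 (0.29 log units; within the scatter), and the other group change gives a 1.9-fold higher number from compound 2 to compound 4 (0.27 log units; within the scatter), so neither step separates compound 4 from its partner. In a physicochemical assay for solubility, read by LC-MS, in phosphate buffer, with a stated time of 24 h, at pH 6.8 (a lower number here means a less soluble compound, a higher number a more soluble compound), compound 3 gives 310000 nM and compound 4 gives 760000 nM. The same swap also shifts solubility in the physicochemical assay: the measured solubility of compound 3, 310000 nM, and of compound 4, 760000 nM, a 2.5-fold higher number (0.39 log units; beyond the scatter)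

The steps shown do not separate ring size from the ring hetero atom. A 1-methylpiperidin-4-yl group on the carbonyl carbon would separate the two.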